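From benzyl to (furan-3-yl)methyl at the assay limit

A few compounds are considered here, and "the series" means these few. Any claim that something is new, unique, unknown or untested is made for them only; others in the source may bear on it.

Compound 1 `COc1ccc(-c2cc(Cc3cccc(OC)c3)c(=O)n(CC(=O)Nc3ccc(F)cc3)n2)cc1`: > 50000 nM
Compound 2 `COc1ccc(Cc2cc(-c3ccc(C)cc3)nn(CC(=O)Nc3ccc(Br)cc3)c2=O)cc1`: > 50000 nM
Compound 3 `Cc1cc(Cc2ccccc2)c(=O)n(CC(=O)Nc2ccc(Br)cc2)n1`: > 50000 nM

Each of these entries is a limit and not a number. In a functional assay on HL-60 cells (Homo sapiens), read by calcium flux (a lower number here means that less compound is needed, a higher number that more compound is needed for the effect), compound 3 gives > 50000 nM, which is likewise a limit. It has plenty of company: the limit of > 50000 nM in this assay, at which 3 of the 3 values shown sit.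

Compound 4 `Cc1cc(Cc2ccoc2)c(=O)n(CC(=O)Nc2ccc(Br)cc2)n1` differs from compound 3 in one place: furan-3-yl in place of phenyl on a saturated chain carbon bound to an aromatic carbon. In words, furan-3-yl stands in place of phenyl on a saturated chain carbon bound to an aromatic carbon.

No measured step connects any of these compounds, so the data give no direct measure of what such a swap can do. The expectation is for no shift beyond the usual scatter, or at best a small move towards less compound being needed. That expectation rests on compound 3, with its limit of > 50000 nM. The estimated change is an at least 1.2-fold lower number from compound 3 to compound 4 (0.09 log units; that floor lies within the scatter). For compound 4 the expected value is 40000 nM, with an estimated range of 10000 nM to 50000 nM.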

Compound 4, half-maximal effective concentration: > 50000 nM
Compound 4: only a limit was reported; the forecaster's own chance of this, stated with the estimate: 70%; middle value at least 1.2-fold (0.09 log units) from the limit.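

In this assay compound 4 gives > 50000 nM, which is a limit and not a number. Compound 3 also stands at a limit, so the step between compound 3 and compound 4 cannot be read. Left open is how much of either compound the effect actually needs, and whether furan-3-yl and phenyl differ at all.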